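Working notes: from compound 2 to compound 3

This account rests on a few compounds, and the source may have more. Where it says the series, first, only, none or still open, it means among the compounds named here.

Measured so far in a functional assay on OVCAR-3 cells (Homo sapiens) for antiproliferative activity, read by MTT assay, with a stated time of 24 h; a lower number here means a stronger inhibitor, a higher number a weaker inhibitor:
- compound 1 `Cc1ccccc1NNC(=O)c1cccc(NS(=O)(=O)c2cnc(O)nc2O)c1`: > 20000 nM (a limit)
- compound 2 `Cc1ccccc1C(=O)NNC(=O)c1cccc(NS(=O)(=O)c2cnc(O)nc2O)c1`: > 20000 nM (a limit)

Compound 2 gives only a limit and no number, and its standing in this assay is the same as that of compound 1: the limit of > 20000 nM in this assay, at which 2 of the 2 values shown sit. The next structure is compound 3 `O=C(NNC(=O)c1cccc(NS(=O)(=O)c2cnc(O)nc2O)c1)c1cccc(Cl)c1`, not yet measured. The change is 3-chlorophenyl in place of 2-methylphenyl on a carbonyl carbon, with 3-chlorophenyl in place of 2-methylphenyl on a carbonyl carbon. For the measured compounds named here, the only measured step that bears on it is a step that the two limits leave unreadable from compound 1 to compound 2, so no size carries over from it. The expected step that the limit leaves unreadable from compound 2 to compound 3 is therefore no step beyond the scatter, in either direction. That expectation rests on compound 1 and compound 2 both sitting at the limit of > 20000 nM in this assay, at which 2 of the 2 values shown sit. Compound 3 is estimated at 25000 nM, within an expected range of 10000 nM to 60000 nM.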

Compound 3, half-maximal inhibitory concentration: 13500 nM
Compound 3: middle estimate off by 1.9-fold (0.27 log units), on the high side, within the range that was stated.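

In this assay, compound 3 is the first compound shown with a number rather than a limit, so the group on this carbonyl carbon can bring the series into the readable range. Placing 3-chlorophenyl there instead of 2-methylphenyl gives an at least 1.4-fold lower number from compound 2 to compound 3 (0.17 log units; that floor lies within the scatter), and the larger change on the amine nitrogen gives an at least 1.4-fold lower number from compound 1 to compound 3 (0.17 log units; that floor lies within the scatter). Neither step has a readable full size, since both start from a limit: the limit of > 20000 nM in this assay, at which 2 of the 3 values shown sit.

Whether the chlorine, the loss of the methyl or the different ring placement accounts for the number remains open, as the change from compound 2 to compound 3 alters these together. Also open, as far as these compounds go, is how an unsubstituted phenyl, or a phenyl carrying an amine or a carboxylic acid, would read on the same carbonyl carbon in this assay.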